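The compounds below may be only part of what the source reports. "The series", "measured", "known", "first", "only" and "open" are said of these compounds alone.

So far a functional assay, read by spectrophotometry, with a stated time of 5 min (on this read-out higher numbers stand for weaker inhibition and lower numbers for stronger inhibition), has given two values
compound 1 `COc1cc(/C=C/C(=O)C(=Cc2ccc(O)cc2)C(=O)/C=C/c2ccc(O)c(OC)c2)ccc1O` gives 48700000 nM
compound 2 `CCOc1cc(/C=C/C(=O)C(=Cc2ccc(OC)c(OC)c2)C(=O)/C=C/c2ccc(O)c(OCC)c2)ccc1O` gives 53200000 nM

On these numbers compound 2 sits at 53200000 nM and lies within the usual scatter of compound 1, so the two cannot be told apart. Compound 3 `CCOc1cc(/C=C/C(=O)C(=Cc2ccc(O)cc2)C(=O)/C=C/c2ccc(O)c(OCC)c2)ccc1O` has not yet been measured. It differs from compound 2 in one place, with 4-hydroxyphenyl in place of 3,4-dimethoxyphenyl on a double-bonded chain carbon bound to a double-bonded chain carbon. For the measured compounds named here, no two measured compounds differ in one place alone, so the size of this step cannot be read directly from the data. The nearest guide is compound 1, which also carries 4-hydroxyphenyl and gives 48700000 nM in this series. On that basis, no step beyond the scatter is expected in this assay for this change. The expected change (a 1.1-fold lower number from compound 2 to compound 3 (0.03 log units; within the scatter)) is therefore small. For compound 3 the estimated value is 50000000 nM, with an expected range from 22000000 nM to 110000000 nM.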

Compound 3, half-maximal inhibitory concentration: 48000000 nM
Compound 3: the middle estimate sits 1.0-fold (0.02 log units) above what was measured, within the range that was stated.
By their numbers in this assay, from the lowest: compounds 3, 1 and 2 (each within the scatter of the next).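

In this assay, for the compounds shown here, putting 4-hydroxyphenyl in place of 3,4-dimethoxyphenyl on a double-bonded chain carbon bound to a double-bonded chain carbon gives a 1.1-fold lower number from compound 2 to compound 3 (0.04 log units; within the scatter), and this is the first comparison here in which only one place changes. The group that leaves has 10 heavy atoms and no hydrogen-bond donors, while the one that enters has 7 heavy atoms and 1 hydrogen-bond donor, yet the read-out does not separate the two compounds, so at this position this particular exchange leaves no mark that can be told from scatter. No measurement is available that would explain this result.

The compounds shown compare only these two groups at this position, so it remains open whether a 4-aminophenyl or 4-carboxyphenyl group there would also stay within the scatter. A single step on a single core also leaves open whether the same exchange would give a similar result if the ethoxy groups elsewhere on the core were replaced by a longer chain, such as butoxy.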